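Swapping Acetoxy for Amino in a Potent Compound

The source may hold more compounds than are shown below. What is called first, only, known or untested is meant among the compounds shown, and "the series" means these compounds.

In a functional assay on CCRF-CEM cells (Homo sapiens) for inhibition, read by MTT assay, with a stated time of 72 h (a lower number here means a stronger inhibitor, a higher number a weaker inhibitor), compound 1 (`COc1ccc(-c2c(-c3ccc(OC)c(OC)c3OC)c(=O)c2=O)cc1`) gives 2480 nM, compound 3 (`COc1ccc(-c2c(-c3c(OC)cc(OC)cc3OC)c(=O)c2=O)cc1`) gives 850 nM and compound 2 (`COc1ccc(-c2c(-c3cc(OC)c(OC)c(OC)c3)c(=O)c2=O)cc1OC(C)=O`) gives 1.8 nM. Compound 2 therefore holds the lowest of the three numbers, and its gaps to compound 3 and compound 1 both lie well beyond the scatter.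

The next compound to be tested is compound 4 (`COc1ccc(-c2c(-c3cc(OC)c(OC)c(OC)c3)c(=O)c2=O)cc1N`). It carries amino in place of acetoxy on an aromatic carbon, ortho to a methoxy group and meta to a large group: amino in place of acetoxy on an aromatic carbon. Among the compounds with values here, no two measured compounds differ in only one place, so the data give no direct measure of what such a change does in this assay. The starting point is compound 2 at 1.8 nM, and the rest of the structure stays the same. A moderate weakening is expected, though it may not clear the scatter, and the estimated step is a 3.3-fold higher number from compound 2 to compound 4 (0.52 log units; beyond the scatter). For compound 4 the expected value is 6 nM, with an estimated range from 1 nM to 50 nM.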

Compound 4, half-maximal inhibitory concentration: 1.4 nM
The estimate for compound 4 lay 4.3-fold (0.63 log units) above the measured number; measured number inside the range.
By their numbers in this assay, from the lowest: compounds 4 and 2 (each within the scatter of the next); then compound 3; then compound 1.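

In this assay, within the data shown here, amino in place of acetoxy on this aromatic carbon gives a 1.3-fold lower number from compound 2 to compound 4 (0.11 log units; within the scatter), the first comparison here between compounds that differ in only one place. At this position, ortho to a methoxy group, the change removes 4 heavy atoms, brings in 1 and adds a hydrogen-bond donor, yet the two numbers cannot be told apart. No evidence is available on why the two groups give matching numbers.

From the compounds shown here alone, it remains open whether a hydroxyl group, a methylamino group or a bare hydrogen on the same carbon would also stay within the scatter of compound 2. Compound 1 and compound 3 each differ from compound 2 in more than one place, so what the placing of the methoxy groups contributes also stays unresolved.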